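Exchanging the Nitrogen Substituent of Compound 3

A few compounds are considered here, and "the series" means these few. Any claim that something is new, unique, unknown or untested is made for them only; others in the source may bear on it.

Measured in a functional assay on DU-145 cells (Homo sapiens) for cytotoxicity, read by trypan blue exclusion, with a stated time of 96 h; a higher number here means a weaker inhibitor, a lower number a stronger inhibitor:
Compound 1 `COc1ccc(NS(=O)(=O)/C=C/c2c(OC)cc(OC)cc2OC)cc1` gives 200 nM
Compound 2 `COc1cc(OC)c(/C=C/S(=O)(=O)Nc2ccc(OC)c(F)c2)c(OC)c1` gives 200 nM
Compound 3 `COC(=O)C(Nc1cc(NS(=O)(=O)/C=C/c2c(OC)cc(OC)cc2OC)ccc1OC)c1ccc(Cl)cc1` gives 5000 nM

Compound 3 has the highest number of the three and is the weakest inhibitor in this assay, well apart from the other two compounds. The next compound, compound 4 `COc1cc(OC)c(/C=C/S(=O)(=O)Nc2ccc(OC)c(NC(C)C(=O)O)c2)c(OC)c1`, has not yet been measured. It brings 1-carboxyethyl in place of (4-chlorophenyl)(methoxycarbonyl)methyl on a nitrogen on an aromatic ring.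

Among the compounds with values here, only one measured step exists, no change at the digits printed from compound 1 to compound 2 (within the scatter), and it involves a fluoro group, so it says little about this exchange. Within the data shown here, no measured step tests a change on this nitrogen. The expectation therefore rests on compound 3 at 5000 nM and on compound 1 at 200 nM, which has no such substituent. A landing between these two values seems likely. The expected step is a 5.0-fold lower number from compound 3 to compound 4 (0.70 log units; beyond the scatter), toward a stronger inhibitor, though with wide uncertainty. For compound 4 the estimated value is 1000 nM, with an expected range from 150 nM to 7000 nM.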

Compound 4, half-maximal inhibitory concentration: 40 nM
Estimate against measurement, compound 4: 25-fold (1.40 log units) above, and the stated range ends above it.
By their numbers in this assay, from the lowest: compound 4; then compounds 1 and 2 (each within the scatter of the next); then compound 3.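

On the nitrogen on an aromatic ring, the choice of substituent has a large effect in this assay: 1-carboxyethyl in place of (4-chlorophenyl)(methoxycarbonyl)methyl gives a 130-fold lower number from compound 3 to compound 4 (2.10 log units; beyond the scatter) in this series. Substitution on this nitrogen is therefore not unfavourable in itself, since (1-carboxyethyl)amino also gives a 5.0-fold lower number from compound 1 to compound 4 (0.70 log units; beyond the scatter) when it replaces hydrogen and a 5.0-fold lower number from compound 2 to compound 4 (0.70 log units; beyond the scatter) when it replaces fluoro on an aromatic carbon, although these gains are only modest and compound 3 shows that not every substituent here does as well. No measurement shown explains these differences.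

The exchange removes the aromatic ring and the methyl ester together while bringing in a carboxylic acid, so the compounds shown do not separate these changes. A primary amide or hydroxymethyl group in place of the carboxyl, or a longer chain ending in a carboxylic acid, would remain to be assessed.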